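Aryl variation on the shared core: cytotoxicity notes

The source may report more compounds than this note shows. Statements on the series, on what has been measured and on what is new or still open speak of the compounds shown alone.

Measured so far:
compound 1 `CCOC(=O)c1cc2ccc(OCCCCCn3cc(CNC(=O)CCCCC4CCSS4)nn3)cc2oc1=O` — 36.4%
compound 2 `COc1ccc(-c2cc3ccc(OCCCCCn4cc(CNC(=O)CCCCC5CCSS5)nn4)cc3oc2=O)cc1OC` — 46.9%
compound 3 `O=C(CCCCC1CCSS1)NCc1cn(CCCCCOc2ccc3cc(-c4ccc(Br)cc4)c(=O)oc3c2)nn1` — 45.7%

In a functional assay on PC-12 cells (Rattus norvegicus) for cytotoxicity, read by MTT assay, with stated times of 3 h and 2 h, tested at 5 uM (on this read-out lower numbers stand for a weaker effect and higher numbers for a stronger effect at the one concentration tested), compound 1 gives 36.4%, compound 2 gives 46.9% and compound 3 gives 45.7%. Compound 3 stands second highest of the three numbers; its nearest neighbour is compound 2, a number 1.2 percentage points lower from compound 2 to compound 3 (within the scatter), and its furthest is compound 1, a number 9.3 percentage points higher from compound 1 to compound 3 (within the scatter). For the measured compounds named here, the only step beyond the scatter is a number 10.5 percentage points higher from compound 1 to compound 2 (beyond the scatter).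

Compound 4 `O=C(CCCCC1CCSS1)NCc1cn(CCCCCOc2ccc3cc(-c4ccc(Cl)c(Cl)c4)c(=O)oc3c2)nn1` has not yet been measured. It differs from compound 3 in one place: 3,4-dichlorophenyl in place of 4-bromophenyl on an aromatic carbon. Going by the values given here, the steps that bear on this change are the two that put an aryl group in place of the ethoxycarbonyl, a number 9.3 percentage points higher from compound 1 to compound 3 (within the scatter) and a number 10.5 percentage points higher from compound 1 to compound 2 (beyond the scatter), and the one that exchanges one aryl group for another, a number 1.2 percentage points lower from compound 2 to compound 3 (within the scatter), which lies within the scatter. Exchanging one substituted phenyl for another therefore gives no ground to expect a step beyond the scatter in this assay, in either direction. Compound 4 is expected to give about 46%, with a range from 36% to 56%. This estimate means a step of a number 0.3 percentage points higher from compound 3 to compound 4 (within the scatter), expected to stay within the scatter.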

Compound 4, a percentage reported as activity, at one concentration (the size of the read-out at that concentration, not a potency): 54.8%
Compound 4: the middle estimate sits 8.8 percentage points below what was measured; the range from low to high includes it.
By their numbers in this assay, from the lowest: compounds 1, 3, 2 and 4 (each within the scatter of the next, the first and the last beyond it).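

In this assay the exchange of 4-bromophenyl for 3,4-dichlorophenyl gives a number 9.1 percentage points higher from compound 3 to compound 4 (within the scatter) and the exchange of 3,4-dimethoxyphenyl for the same group gives a number 7.9 percentage points higher from compound 2 to compound 4 (within the scatter), so the three aryl groups on this aromatic carbon still cannot be separated from one another pairwise. What is new is a number 18.4 percentage points higher from compound 1 to compound 4 (beyond the scatter), which makes 3,4-dichlorophenyl the second aryl group, after the 3,4-dimethoxyphenyl of compound 2, whose step from the ethoxycarbonyl of compound 1 leaves the scatter, while compound 3 goes against any general rule for aryl in place of ethoxycarbonyl, since its step stays within the scatter. No measurement in hand accounts for these differences.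

A 4-chlorophenyl group would separate the effect of the kind of halogen from that of the number of halogens, and a carboxylic acid or an amine at this carbon would test groups far from both the aryl groups and the ethoxycarbonyl. On these data alone, whether a longer chain between the shared core and the triazole-bearing part would shift these numbers also remains open, and a read-out at a single concentration gives no potency for any of the four compounds.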